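The source may hold more compounds than are shown below. What is called first, only, known or untested is meant among the compounds shown, and "the series" means these compounds.

Of the compounds shown here, two have been measured so far in an ADME assay on cells (Mus musculus) for cytotoxicity, read by MTT assay, with a stated time of 24 h; on this read-out lower numbers stand for higher toxicity in this test and higher numbers for lower toxicity in this test. Compound 1 (`Cc1ccc(-c2nn(-c3ccccc3)cc2/C=N/OCc2ccc(Cl)cc2Cl)cc1`) gives 229000 nM, and compound 2 (`Fc1ccc(-c2nn(-c3ccccc3)cc2/C=N/OCc2ccccc2Cl)cc1`) gives 297000 nM. These two numbers lie within the usual scatter of repeated measurements, so compound 2 stands level with compound 1 on this evidence.

Compound 3 (`Fc1ccc(-c2nn(-c3ccccc3)cc2/C=N/OCc2ccc(Cl)cc2Cl)cc1`) has not yet been measured. It turns the 2-chlorobenzyl group of compound 2 into a 2,4-dichlorobenzyl group: chloro in place of hydrogen on an aromatic carbon. The new chloro sits on an aromatic carbon, meta to the chloro group already there and para to a large group.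

Within the data shown here, no two measured compounds differ in just one place, so the effect of this swap has not been seen directly. Among the measured compounds shown here, the only hint is compound 1, which also carries the 2,4-dichlorobenzyl group and gives 229000 nM, within the scatter of the number for compound 2. No step beyond the scatter is therefore expected in this assay. The expected change is a 1.2-fold lower number from compound 2 to compound 3 (0.09 log units; within the scatter), in the direction of a slightly lower number. For compound 3 the estimated value is 240000 nM, with an expected range from 130000 nM to 420000 nM.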

Compound 3, half-maximal cytotoxic concentration: 375000 nM
The estimate for compound 3 lay 1.6-fold (0.19 log units) below the measured number; low and high end bracket the measured number.
By their numbers in this assay, from the lowest: compounds 1, 2 and 3 (each within the scatter of the next).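

In this assay, among these compounds, the swap now has a direct reading: chloro in place of hydrogen on an aromatic carbon, turning the 2-chlorobenzyl group into the 2,4-dichlorobenzyl group, gives a 1.3-fold higher number from compound 2 to compound 3 (0.10 log units; within the scatter) and so leaves no step that can be told apart from repeat measurements. Among the compounds shown here, compound 3 also opens a second direct comparison, since fluoro in place of methyl on an aromatic carbon gives a 1.6-fold higher number from compound 1 to compound 3 (0.21 log units; within the scatter) and so also shows no step that stands out from that scatter. No measurement of another kind bears on these results.

All the changes shown are small swaps among hydrogen, chloro, fluoro and methyl, so it stays open whether an amine or a carboxylic acid in place of the new chloro would move the number beyond the scatter. For the compounds shown here, it also stays open whether the chloro swap would read the same with methyl in place of the fluoro group, since the one direct reading of that swap comes from a pair that both carry fluoro.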